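The source may hold more compounds than are shown below. What is called first, only, known or untested is meant among the compounds shown, and "the series" means these compounds.

Of the compounds shown here, three have been tested so far in a functional assay on HCT-116 cells (Homo sapiens) for antiproliferative activity, read by CellTiter-Glo, with a stated time of 72 h; a higher number here means a weaker inhibitor, a lower number a stronger inhibitor. Compound 1 `O=C(NO)c1cccc(/C=C/c2ccnc(-c3cc(F)ccc3O)c2)c1` gives 3890 nM in this assay. Compound 2 `O=C(NO)c1cccc(/C=C/c2ccnc(-c3ccccc3O)c2)c1` gives 3360 nM in this assay. For compound 3 `Cc1ccc(-c2cc(/C=C/c3ccc(C(=O)NO)cc3)c(F)cn2)cc1` this assay reports only a limit, > 10000 nM, and not a number. The difference between the core of compound 2 and the core of compound 3 is not broken down here.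

The change from compound 2 to compound 1 is fluoro in place of hydrogen on an aromatic carbon. That step came to a 1.2-fold higher number from compound 2 to compound 1 (0.06 log units; within the scatter), so the two values are not told apart.

Compound 4 `Cc1ccc(-c2cc(/C=C/c3ccc(C(=O)NO)cc3)c(F)cn2)c(F)c1` has not been measured yet. It differs from compound 3 by fluoro in place of hydrogen on an aromatic carbon. Among the measured compounds shown here, this is the same kind of change as the one from compound 2 to compound 1, but the surroundings differ: in compound 1 the fluoro sits meta to a large group and para to a hydroxy group, whereas in compound 4 it sits ortho to a large group and meta to a methyl group.

Because the measured instance of this change, a 1.2-fold higher number from compound 2 to compound 1 (0.06 log units; within the scatter), lay within the scatter, the expectation for compound 4 rests on compound 3 staying about where it is. The step from compound 3 to compound 4 in this assay is expected to be a step that the limit leaves unreadable from compound 3 to compound 4. Since compound 3 sits at the limit of > 10000 nM in this assay, at which 1 of the 3 values shown sits, compound 4 is estimated at 15000 nM, with a range from 6000 nM to 40000 nM, and it is likely that this assay again reports only a limit.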

Compound 4, half-maximal inhibitory concentration: 1670 nM
The estimate for compound 4 lay 9.0-fold (0.95 log units) above the measured number; measured number outside the range, below it.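

In this assay, fluoro in place of hydrogen on an aromatic carbon, here 4-methylphenyl to 2-fluoro-4-methylphenyl, gives an at least 5.9-fold lower number from compound 3 to compound 4 (0.77 log units; beyond the scatter). Compound 3 has only a limit, > 10000 nM, and not a number, so this step gives a smallest possible size and not the true one. The two cases show that the size of this change does not carry over unaltered from one core to another in this series, but they do not show why, since the fluoro stands in different surroundings in each, and they cannot predict the step on a third core: the same change on two cores in this assay, a 1.2-fold higher number (0.06 log units; within the scatter) from compound 2 to compound 1 and an at least 5.9-fold lower number (0.77 log units; beyond the scatter) from compound 3 to compound 4, at least 6.9-fold (0.84 log units) apart, beyond the scatter of two such steps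

The compounds shown leave open whether this step belongs to fluoro itself or would also appear with another group in the same place, such as chloro or methoxy. They also leave open whether a fluoro ortho to a large group would give a similar step on the core of compound 2, which would help separate the effect of the core from that of the place on the ring.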